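Removing a Methoxy Group from a Compound at the Limit

The compounds below may be only part of what the source reports. "The series", "measured", "known", "first", "only" and "open" are said of these compounds alone.

Compound 2 `COc1cccc(-c2cc(-c3cc4cc(OC)ccc4[nH]3)no2)c1` is one of three compounds tested in a functional assay on Calu-3 cells (Homo sapiens) for cytotoxicity, read by WST assay, with a stated time of 72 h; on this read-out lower numbers stand for stronger inhibition and higher numbers for weaker inhibition. In this assay compound 2 gives > 100000 nM, which is a limit of the assay rather than a number. The same holds for compound 1 `COc1ccc(-c2cc(-c3cc4ccccc4n3C)no2)cc1`, which in this assay gives > 100000 nM, again a limit. Compound 3 `COc1ccc(-c2cc(-c3c(Cl)c4ccccc4n3C)no2)cc1` gives 60900 nM in this assay, a measured number. Two of the three values thus sit at the limit of > 100000 nM in this assay, at which 2 of the 3 values shown sit, so compound 2 stands at the weak end of what has been seen here, without a number of its own.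

Compound 4 `COc1cccc(-c2cc(-c3cc4ccccc4[nH]3)no2)c1` differs from compound 2 by hydrogen in place of methoxy on an aromatic carbon. Going by the values given here, the only step measured between two compounds that differ in a single place is an at least 1.6-fold lower number from compound 1 to compound 3 (0.21 log units; that floor lies within the scatter); it concerns chloro replacing hydrogen, not the loss of a methoxy, and even its floor lies within the scatter. Among the compounds with values here, no measured step therefore speaks directly to the change from compound 2 to compound 4.

Compound 4 is accordingly expected to remain close to the limit seen for its parent, and the step of a number no higher from compound 2 to compound 4 (the limit leaves the size open) is expected to be small. The estimate for compound 4 is 100000 nM, with a range from 40000 nM to 300000 nM.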

Compound 4, half-maximal inhibitory concentration: > 100000 nM
Compound 4 gave a limit, no number; the forecaster's own chance of this, stated with the estimate: 65%; the middle value lies on the limit itself.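

Going by these compounds alone, compound 2 and compound 4 each give only a limit of the assay rather than a number, so no step between them can be read. The compounds shown leave open how weak either compound really is, and so whether hydrogen in place of methoxy changes the result at all: the limit of > 100000 nM in this assay, at which 3 of the 4 values shown sit.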